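The compounds below may be only part of what the source reports. "The series", "measured", "known", "first", "only" and "open" are said of these compounds alone.

Going by the values given here, in an ADME assay on THP-1 cells (Homo sapiens) for cytotoxicity, read by trypan blue exclusion, with a stated time of 48 h (a higher number here means a weaker inhibitor of growth, a lower number a stronger inhibitor of growth), compound 3 `Cc1c(CN2CCN(C)CC2)cc(-c2ccc(Cl)cc2)n1-c1ccc(Cl)cc1` gives 3.23 ug/mL, the lowest of the three numbers so far, against compound 2 `Cc1cc(CN2CCN(c3ccccc3)CC2)c(C)n1-c1ccc(Cl)cc1` at 25 ug/mL and compound 1 `Cc1c(CN2CCN(C3CC4CCC3C4)CC2)cc(-c2ccc(Cl)cc2)n1-c1ccc(Cl)cc1` at 429 ug/mL. Compound 4 `Cc1c(CN2CCN(c3ccccc3)CC2)cc(-c2ccc(Cl)cc2)n1-c1ccc(Cl)cc1` departs from compound 3 by phenyl in place of methyl on an amine nitrogen in a ring. Among the compounds with values here, the only measured step at that nitrogen is a 130-fold lower number from compound 1 to compound 3 (2.12 log units; beyond the scatter), a large one, so a larger group there has gone with a higher number. Compound 2 carries the same phenyl on a different core and reads 25 ug/mL. A clear rise is therefore expected in this assay, though smaller than that large step. The expected change is a 9.3-fold higher number from compound 3 to compound 4 (0.97 log units; beyond the scatter). For compound 4 the estimated value is 30 ug/mL, within an expected range of 6 ug/mL to 200 ug/mL.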

Compound 4, concentration for 50% growth inhibition: 294 ug/mL
Compound 4: middle estimate off by 9.8-fold (0.99 log units), on the low side, and the stated range ends below it.
By their numbers in this assay, from the lowest: compound 3; then compound 2; then compounds 4 and 1 (each within the scatter of the next).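

In this assay, phenyl in place of methyl on an amine nitrogen in a ring brings a 91-fold higher number from compound 3 to compound 4 (1.96 log units; beyond the scatter) and so takes the number close to that of compound 1: the step for phenyl in place of the group that compound 1 carries at that nitrogen is a 1.5-fold lower number from compound 1 to compound 4 (0.16 log units; within the scatter) and lies within the scatter. With phenyl held at that nitrogen, 4-chlorophenyl in place of methyl on an aromatic carbon gives a 12-fold higher number from compound 2 to compound 4 (1.07 log units; beyond the scatter) as well, so the core also counts. From the compounds shown here alone, whether an ethyl or a hydroxyethyl group at that nitrogen would stay near compound 3 or move towards compound 4 remains open. Nothing available explains these shifts.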